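From 4-fluorobenzyl to 4-methylphenyl on an aromatic nitrogen

A few compounds are considered here, and "the series" means these few. Any claim that something is new, unique, unknown or untested is made for them only; others in the source may bear on it.

Compound 1 `COc1ccc(C[C@H]2COC(=O)[C@@H]2Cc2ccc(OCC(=O)Nc3ccc(C)cc3)c(OC)c2)cc1OC` gives 228000 nM
Compound 2 `COc1ccc(C[C@H]2COC(=O)[C@@H]2Cc2ccc(OCC(=O)N3CCCCC3)c(OC)c2)cc1OC` gives 293000 nM
Compound 3 `COc1ccc(C[C@H]2COC(=O)[C@@H]2Cc2ccc(OCc3cn(Cc4ccc(F)cc4)nn3)c(OC)c2)cc1OC` gives 198000 nM

These three values come from an ADME assay on HeLa cells (Homo sapiens) for cytotoxicity, read by MTT assay (a lower number here means a stronger inhibitor, a higher number a weaker inhibitor), and lie within the usual scatter of one another. Compound 3 therefore stands level with both compound 1 and compound 2 on these numbers, and nothing separates the three.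

Within the data shown here, the next compound is compound 4 `COc1ccc(C[C@H]2COC(=O)[C@@H]2Cc2ccc(OCc3cn(-c4ccc(C)cc4)nn3)c(OC)c2)cc1OC` which carries 4-methylphenyl in place of 4-fluorobenzyl on an aromatic nitrogen and no measured pair shows this change on its own.

Among the measured compounds shown here, only one measured step links compounds that differ in a single place. It is a 1.3-fold higher number from compound 1 to compound 2 (0.11 log units; within the scatter) and it concerns a carbonyl carbon, not the aromatic nitrogen, so it bears on the new change only indirectly. It does show a swap of one large group for another that stays within the scatter in this assay and the three measured compounds, with their different groups, stay close together. No step beyond the scatter is therefore expected, and no direction can be argued from these data.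

The step expected on this reasoning is a 1.1-fold higher number from compound 3 to compound 4 (0.03 log units; within the scatter) in this assay and it rests on the close values above.

For compound 4 the estimated value is 210000 nM with an expected range from 120000 nM to 360000 nM in this assay as measured.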

Compound 4, half-maximal inhibitory concentration: >= 600000 nM
Compound 4 ended at the assay's limit; the forecaster's own chance of this, stated with the estimate: 10%; middle value at least 2.8-fold (0.45 log units) from the limit.
By their numbers in this assay, from the lowest: compounds 3, 1 and 2 (each within the scatter of the next). At a limit, above all of these: compound 4.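

In this assay compound 4 sits at a limit of the assay rather than at a number: the limit of >= 600000 nM in this assay, at which 1 of the 4 values shown sits. Placing 4-methylphenyl in place of 4-fluorobenzyl on an aromatic nitrogen gives an at least 3.0-fold higher number from compound 3 to compound 4 (0.48 log units; beyond the scatter), the first step in the series to pass beyond the scatter, whereas the change on a carbonyl carbon gave only a 1.3-fold higher number from compound 1 to compound 2 (0.11 log units; within the scatter). The group 1-(4-methylphenyl)-1H-1,2,3-triazol-4-yl also separates compound 4 from the other two compounds, with an at least 2.0-fold higher number from compound 2 to compound 4 (0.31 log units; beyond the scatter) where it replaces (piperidin-1-yl)carbonyl and an at least 2.6-fold higher number from compound 1 to compound 4 (0.42 log units; beyond the scatter) where it replaces (4-methylphenyl)carbamoyl.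

On these data alone, how far compound 4 lies past the limit stays open, so each of these steps has a lower bound but no known size. The change also alters two things at once, the group on the phenyl ring and the carbon link to the aromatic nitrogen, and 4-methylbenzyl or 4-fluorophenyl on the same nitrogen would be needed to tell these two apart.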